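A few compounds are considered here, and "the series" means these few. Any claim that something is new, unique, unknown or untested is made for them only; others in the source may bear on it.

Measured compounds:
Compound 1, `COc1cccc(OC)c1OCCNCCOc1ccccc1OCc1ccccc1Cl`, 7.52
Compound 2, `COc1cccc(OC)c1OCCNCCOc1ccccc1OCc1ccccc1[N+](=O)[O-]`, 8.56

Compound 2 gives the higher of the two numbers in a functional assay on spleen for antagonist activity at Alpha-1B adrenergic receptor (Rattus norvegicus); on this read-out lower numbers stand for lower potency and higher numbers for higher potency (the scale is a negative logarithm); compound 1 sits a step below, a number 1.04 log units higher from compound 1 to compound 2 (beyond the scatter). Compound 3, `COc1ccccc1COc1ccccc1OCCNCCOc1c(OC)cccc1OC`, is not yet measured; it differs from compound 2 by methoxy in place of nitro on an aromatic carbon. Among the measured compounds shown here, no measured step covers this exchange; the one step known, from chloro to nitro, was large and raised the read-out. Removing the nitro of compound 2 is therefore expected to cost potency, by about a number 0.86 log units lower from compound 2 to compound 3 (beyond the scatter). Compound 3 is estimated at 7.7, within 7 to 8.4.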

Compound 3, negative logarithm of the antagonist equilibrium constant: 8.13
For compound 3 the middle estimate is 0.43 log units below the measured one; the measured number falls inside the stated range.
By their numbers in this assay, from the lowest: compound 1; then compound 3; then compound 2.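

Methoxy on this aromatic carbon keeps much of the potency in this assay: replacing nitro costs only a modest amount (a number 0.43 log units lower from compound 2 to compound 3 (beyond the scatter)), while replacing chloro gains a modest amount (a number 0.61 log units higher from compound 1 to compound 3 (beyond the scatter)). The three groups therefore fall into an order at this one position, with nitro above methoxy and methoxy above chloro, so nitro is not the only one of them that outperforms chloro. Nothing measured here explains this order. The compounds shown do not tell where an amine or a carboxylic acid on this carbon would fall relative to these three groups.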